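This account rests on a few compounds, and the source may have more. Where it says the series, first, only, none or still open, it means among the compounds named here.

In a functional assay on PC-12 cells (Rattus norvegicus) for cytotoxicity, read by MTT assay, with a stated time of 24 h (a higher number here means that more compound is needed for the effect, a lower number that less compound is needed), compound 1 `COc1ccc(N2CCN(CC#CCOC(=O)c3sc4ncnc(N5CCCCC5)c4c3C)CC2)cc1` gives 35.3 ug/mL and compound 2 `Cc1c(-c2nnc(-c3ccccc3)o2)sc2ncnc(N3CCCCC3)c12` gives 22.1 ug/mL so these two values lie within the usual scatter of each other and do not separate the compounds. The step to compound 3 `Cc1ccc(-c2nnc(-c3sc4ncnc(N5CCCCC5)c4c3C)o2)cc1` is methyl in place of hydrogen on an aromatic carbon and amounts to methyl in place of hydrogen on an aromatic carbon, turning phenyl into 4-methylphenyl. Among the measured compounds shown here, no measured pair shows this change, so the data give no direct size for it. No step beyond the scatter is expected in this assay and no direction is favoured. The estimate is anchored on compound 2 at 22.1 ug/mL as the closest measured structure. The expected change is a 1.0-fold lower number from compound 2 to compound 3 (0.00 log units; within the scatter) and stays within the scatter. For compound 3 the estimated value is 22 ug/mL with an expected range from 11 ug/mL to 44 ug/mL in this measurement.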

Compound 3, half-maximal effective concentration: 28.2 ug/mL
The estimate for compound 3 lay 1.3-fold (0.11 log units) below the measured number; measured number inside the range.
By their numbers in this assay, from the lowest: compounds 2, 3 and 1 (each within the scatter of the next).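

In this assay, among the compounds shown here, the step of a 1.3-fold higher number from compound 2 to compound 3 (0.11 log units; within the scatter) gives the first one-place reading, with methyl in place of hydrogen on an aromatic carbon, para to a large group. Turning phenyl into 4-methylphenyl leaves the number within the scatter, so this single added carbon has no measurable effect at this position. For the compounds shown here, no pair among the earlier compounds differed in one place, and they could not give this reading. No evidence bearing on this result is at hand.

From the compounds shown here alone, whether the position accepts change more broadly stays open, as one methyl says nothing about an amine, a carboxylic acid or a chlorine atom there. Also open, going by these compounds, is whether a longer chain, such as butyl, would move the number beyond the scatter.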